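A few compounds are considered here, and "the series" means these few. Any claim that something is new, unique, unknown or untested is made for them only; others in the source may bear on it.

Measured so far in an ADME assay on Akata cells (Homo sapiens) for cytotoxicity, with a stated time of 7 days; a lower number here means that less compound is tolerated, a higher number that more compound is tolerated:
Compound 1 `Nc1nc(NC2CC2)c2ncn(/C=C3/CC3(CO)CO)c2n1` gives a limit, > 20000 nM.
Compound 2 `CC(C)CSc1nc(N)nc2c1ncn2/C=C1/CC1(CO)CO` gives a limit, > 20000 nM.
Compound 3 `CC(C)CNc1nc(N)nc2c1ncn2/C=C1/CC1(CO)CO` gives a limit, > 24000 nM.

Compound 3 thus stands at a limit, as do the other two values: all three sit at the limit of > 20000 nM in this assay, at which 2 of the 3 values shown sit, or (the limit of > 24000 nM in this assay, at which 1 of the 3 values shown sits). Compound 4 `CCCOc1nc(N)nc2c1ncn2/C=C1/CC1(CO)CO` differs from compound 3 in one place: propoxy in place of isobutylamino on an aromatic carbon. Among the measured compounds shown here, the steps that bear on this carbon are a step that the two limits leave unreadable from compound 1 to compound 2, a step that the two limits leave unreadable from compound 1 to compound 3 and a step that the two limits leave unreadable from compound 2 to compound 3; none is readable in size, as every end is a limit. No shown step brings the number under the limit, so compound 4 is expected to stay at the limit too, with an expected step that the limit leaves unreadable from compound 3 to compound 4. Compound 4 is estimated at 25000 nM, between 15000 nM and 60000 nM.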

Compound 4, half-maximal cytotoxic concentration: > 20000 nM
Compound 4: only a limit was reported; the forecaster's own chance of this, stated with the estimate: 85%; the middle value is on the limit's open side.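

The steps from compound 1, compound 2 and compound 3 to compound 4 cannot be read, as all four values in this assay are limits. The compounds shown leave open whether any group on this aromatic carbon brings the half-maximal cytotoxic concentration to a readable number.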